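This account rests on a few compounds, and the source may have more. Where it says the series, first, only, none or still open, it means among the compounds named here.

Compound 1 `CC1=C(C(=O)CC(C)C)C(c2ccco2)NC(=O)N1` gives 31% in an assay on membranes from HeLa cells for displacement of a labelled ligand from adenosine receptor A3 (Homo sapiens), read by scintillation counting, with a stated time of 180 min, tested at 1 uM (on this read-out higher numbers stand for more inhibition at the one concentration tested (going by the name of the read-out) and lower numbers for less inhibition), the highest of the three numbers in hand. Compound 2 `CC1=C(C(=O)CC(C)C)C(c2ccsc2)NC(=O)N1` gives 14% and compound 3 `CCN(CC)C(=O)C1=C(C)NC(=O)NC1c1ccco1` gives 19%; the steps of a number 17 percentage points lower from compound 1 to compound 2 (beyond the scatter) and a number 12 percentage points lower from compound 1 to compound 3 (beyond the scatter) both lie beyond the scatter. Compound 4 `CC1=C(c2ncc(C)o2)C(c2ccco2)NC(=O)N1` differs from compound 1 by 5-methyl-1,3-oxazol-2-yl in place of isobutylcarbonyl on a double-bonded ring carbon. Among the compounds with values here, only the step to compound 3 bears on this, since it too alters the isobutylcarbonyl group, and it cost a number 12 percentage points lower from compound 1 to compound 3 (beyond the scatter); the present change removes that carbonyl entirely and brings in an aromatic ring, a larger departure than either measured step. Compound 4 is therefore expected to show a modest drop, a number 13 percentage points lower from compound 1 to compound 4 (beyond the scatter), with an estimated 18%, between 5% and 34%.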

Compound 4, a percentage reported as inhibition, at one concentration (the size of the read-out at that concentration, not a potency): 4%
Estimate against measurement, compound 4: 14 percentage points above; measured number below the stated range.
By their numbers in this assay, from the lowest: compounds 4, 2 and 3 (each within the scatter of the next, the first and the last beyond it); then compound 1.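

At this place on the double-bonded ring carbon, an aromatic 5-methyl-1,3-oxazol-2-yl with the same heavy-atom count as isobutylcarbonyl still gives a number 27 percentage points lower from compound 1 to compound 4 (beyond the scatter) in this assay. Heavy-atom count alone therefore does not preserve the number, and a lower number now follows both the diethylamino amide of compound 3 and this replacement, which has no carbonyl. Nothing available explains the drop.

The compounds shown leave open how a methyl ester or a longer ketone chain would read at this place. They also leave open whether an unsubstituted oxazole would differ from compound 4.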